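Chloro for fluoro on two related cores

This account rests on a few compounds, and the source may have more. Where it says the series, first, only, none or still open, it means among the compounds named here.

Measured so far:
compound 1 `O=C1/C(=C/c2cccc(F)c2)CCc2cc(O)ccc21` gives 1230 nM in a functional assay on RAW264.7 cells (Mus musculus) for inhibition; a higher number here means a weaker inhibitor, a lower number a stronger inhibitor
compound 2 `O=C1/C(=C/c2cccc(Cl)c2)CCc2cc(O)ccc21` gives 1750 nM in this assay
compound 3 `O=C1/C(=C/c2cccc(F)c2)CCc2ccc(O)cc21` gives 830 nM in this assay

Compounds 1 and 2 share one core; compound 3 sits on a second core built from the same atoms joined differently. The difference between the two cores is not broken down here. Within the first core, the change from compound 1 to compound 2 is chloro in place of fluoro on an aromatic carbon, and it made a 1.4-fold higher number from compound 1 to compound 2 (0.15 log units; within the scatter). Compound 4 `O=C1/C(=C/c2cccc(Cl)c2)CCc2ccc(O)cc21`, not yet measured, carries the corresponding change on the core of compound 3: chloro in place of fluoro on an aromatic carbon. The place is described in the same words for both pairs, so this is the same change, seen twice among the compounds shown.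

On the values of the two cores: compound 3 and compound 1 stand within the scatter of each other, so nothing is said about their order; compound 3 against compound 2 lies beyond the scatter, with compound 2 giving the higher number.

Only one measured occurrence of the change exists, so the expectation for the second rests on it alone. The step from compound 3 to compound 4 is expected to be a 1.4-fold higher number from compound 3 to compound 4 (0.14 log units; within the scatter) in this assay, because the same change made a 1.4-fold higher number from compound 1 to compound 2 (0.15 log units; within the scatter), a step within the scatter. Scatter on both the anchor and the step widens the range. For compound 4 the estimate in this assay is 1150 nM, with the range from 600 nM to 2300 nM.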

Compound 4, half-maximal inhibitory concentration: 210 nM
For compound 4 the middle estimate is 5.5-fold (0.74 log units) above the measured one, and the stated range ends above it.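

Chloro in place of fluoro on an aromatic carbon did not carry over unchanged between the two cores in this assay. On the second core the change made a 4.0-fold lower number from compound 3 to compound 4 (0.60 log units; beyond the scatter), and the two occurrences differ by more than scatter allows: the same change on two cores in this assay, a 1.4-fold higher number (0.15 log units; within the scatter) from compound 1 to compound 2 and a 4.0-fold lower number (0.60 log units; beyond the scatter) from compound 3 to compound 4, 5.6-fold (0.75 log units) apart, beyond the scatter of two such steps

The step on the first core lies within the scatter, so the contrast is between a step with no readable change and a clear fall in the number, not between two firm moves in opposite directions, and a step measured on one of these cores is a poor guide to the same change on the other. Among the compounds shown here, with only one pair on each core, this does not show why the cores differ, nor does it establish a general rule for the series or for any other change.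

The compounds shown leave open whether the lower number on the second core is particular to chloro or also appears with bromo, methyl or a nitrile at the same place. Also open, from the compounds shown here alone, is how either core responds when its hydroxyl is replaced by a methoxy group or an amine, which would show whether the difference between the cores extends beyond this one pair of halogens.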